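This account rests on a few compounds, and the source may have more. Where it says the series, first, only, none or still open, it means among the compounds named here.

Three members of the series have been run in an ADME assay on HCT-116 cells (Homo sapiens) for cytotoxicity; on this read-out lower numbers stand for higher toxicity in this test and higher numbers for lower toxicity in this test: compound 1 `Cc1ccc(-n2c(SCC(=O)NNC(=O)c3ccccc3O)nnc2-c2ccccc2O)cc1`, compound 2 `O=C(CSc1nnc(-c2ccccc2O)n1Cc1ccccc1)NNC(=O)c1ccccc1O` and compound 3 `O=C(CSc1nnc(Cc2ccccc2)n1-c1cccc(Cl)c1)NNC(=O)c1ccccc1O`. In this assay compound 1 gives > 20000 nM, which is a limit of the assay and not a number. Compound 2 gives > 20000 nM in this assay, again a limit. Compound 3 gives > 20000 nM in this assay, also a limit. Within the data shown here, the single measured step, a step that the two limits leave unreadable from compound 1 to compound 2, therefore has no readable size, and the limit of > 20000 nM in this assay, at which 3 of the 3 values shown sit, is all the numbers show. Compound 3 thus stands at the limit. Compound 4 `COc1ccc(-n2c(Cc3ccccc3)nnc2SCC(=O)NNC(=O)c2ccccc2O)cc1` differs from it by 4-methoxyphenyl in place of 3-chlorophenyl on an aromatic nitrogen. Among the measured compounds shown here, no measured step bears on this change. Compound 4 is therefore expected to stay at the limit as well, with an expected step that the limit leaves unreadable from compound 3 to compound 4. The estimate for compound 4 in this assay is 30000 nM, with a range from 15000 nM to 100000 nM.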

Compound 4, half-maximal cytotoxic concentration: > 20000 nM
Compound 4 was reported as a limit; the forecaster's own chance of this, stated with the estimate: 85%; the middle value is on the limit's open side.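

No new step can be read, since compound 3 and compound 4 are both reported only as limits. The compounds shown leave open whether any change on this series brings a measurable value: the limit of > 20000 nM in this assay, at which 4 of the 4 values shown sit.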